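Changing the Ring on the Amide Carbonyl: What to Expect

The source may report more compounds than this note shows. Statements on the series, on what has been measured and on what is new or still open speak of the compounds shown alone.

Measured so far, in a functional assay on A549 cells (Homo sapiens) for antiproliferative activity, read by CCK-8 assay, with a stated time of 72 h; a lower number here means a stronger inhibitor, a higher number a weaker inhibitor:
compound 1 `O=C(Nc1cccc(-c2oc3cc(-c4ccc(F)cc4)ccc3c(=O)c2O)c1)c1ccc(Br)cc1` gives 13500 nM
compound 2 `O=C(Nc1cccc(-c2oc3cc(-c4ccc(F)cc4)ccc3c(=O)c2O)c1)c1ccc(Br)cc1F` gives 46100 nM

Compound 2 has the higher of the two numbers, which is the weaker result. Among the compounds with values here, the only measured step, a 3.4-fold higher number from compound 1 to compound 2 (0.53 log units; beyond the scatter), came from fluoro in place of hydrogen on an aromatic carbon. Compound 3 `Cc1cc(C(=O)Nc2cccc(-c3oc4cc(-c5ccc(F)cc5)ccc4c(=O)c3O)c2)ccc1F` differs from compound 2 by 4-fluoro-3-methylphenyl in place of 4-bromo-2-fluorophenyl on a carbonyl carbon. Within the data shown here, that step removes the fluoro that raised the number, but also exchanges bromine for fluorine and adds a methyl, and no measured pair covers those parts. The expected outcome is a 2.3-fold lower number from compound 2 to compound 3 (0.36 log units; beyond the scatter), a return towards compound 1. Compound 3 is estimated at 20000 nM, within 6000 nM to 60000 nM.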

Compound 3, half-maximal inhibitory concentration: 11500 nM
The estimate for compound 3 lay 1.7-fold (0.24 log units) above the measured number, and the stated range covers the measured number.
By their numbers in this assay, from the lowest: compounds 3 and 1 (each within the scatter of the next); then compound 2.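

In this assay this position on the carbonyl carbon can recover from the weak result of compound 2 without keeping bromine: 4-fluoro-3-methylphenyl in place of 4-bromo-2-fluorophenyl gave a 4.0-fold lower number from compound 2 to compound 3 (0.60 log units; beyond the scatter) at this site. The ring can also change substantially with no clear effect, as 4-fluoro-3-methylphenyl in place of 4-bromophenyl gave a 1.2-fold lower number from compound 1 to compound 3 (0.07 log units; within the scatter) here. No measurement available here explains either step. The bromine, fluoro and methyl changes are not separated by these compounds. From the compounds shown here alone, how an amine or a carboxylic acid on this ring would read remains open.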